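Phenylsulfonyl ester replaces hydroxyethyl ether on the shared core

The source may report more compounds than this note shows. Statements on the series, on what has been measured and on what is new or still open speak of the compounds shown alone.

Measured so far:
compound 1 `CCC(CC)(c1ccc(OCCO)c(C)c1)c1ccc(OCC(O)C(C)(C)C)c(OCC(O)C(C)(C)C)c1`, 38%
compound 2 `CCC(CC)(c1ccc(OCC(=O)O)c(C)c1)c1ccc(OCC(O)C(C)(C)C)c(OCC(O)C(C)(C)C)c1`, 10%
compound 3 `CCC(CC)(c1ccc(OCCCCC(=O)O)c(C)c1)c1ccc(OCC(O)C(C)(C)C)c(OCC(O)C(C)(C)C)c1`, "not active" (no number reported)

In an assay on cells for binding affinity to vitamin D3 receptor (Homo sapiens), read by fluorescence, tested at 1 uM (a lower number here means less inhibition, a higher number more inhibition at the concentration tested (going by the name of the read-out)), compound 1 stands highest of the two numbers; its nearest neighbour is compound 2, and the step of a number 28 percentage points lower from compound 1 to compound 2 (beyond the scatter) lies beyond the scatter. Compound 3 gives only "not active" (no number reported) in this assay, without a number.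

Compound 4 `CCC(CC)(c1ccc(OS(=O)(=O)c2ccccc2)c(C)c1)c1ccc(OCC(O)C(C)(C)C)c(OCC(O)C(C)(C)C)c1` differs from compound 1 in one place: phenylsulfonyl in place of 2-hydroxyethyl on an oxygen on an aromatic ring. Among the compounds with values here, no measured step matches this change exactly. Within the data shown here, the only step that bears on it is a number 28 percentage points lower from compound 1 to compound 2 (beyond the scatter), where the hydroxyl-bearing chain was also altered and the reading fell. Compound 4 loses the donor as well, so a drop is expected, a number 20 percentage points lower from compound 1 to compound 4 (beyond the scatter). Compound 4 is therefore estimated at 18%, between 3% and 38%.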

Compound 4, a percentage reported as inhibition, at one concentration (the size of the read-out at that concentration, not a potency): "not active" (no number reported)
Compound 4: no number reported; the estimate stays without a comparison.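

In this assay, within the data shown here, compound 4 gives "not active" (no number reported) and compound 3 gives "not active" (no number reported) so no step from compound 1 to either can be read. No measurement shown here accounts for this result. The compounds shown leave open how far compound 4 and compound 3 lie under compound 1 in number.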